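The compounds below may be only part of what the source reports. "The series", "measured", "known", "first", "only" and "open" are said of these compounds alone.

Measured in a functional assay on MCF7 cells (Homo sapiens) for antiproliferative activity, with a stated time of 96 h; on this read-out lower numbers stand for stronger inhibition and higher numbers for weaker inhibition:

- compound 1 `Cc1cc(=O)oc2cc(OCC(=O)c3ccc(C(C)(C)C)cc3)ccc12`: 20700 nM
- compound 2 `Cc1cc(=O)oc2cc(OCC(=O)c3ccccc3C(F)(F)F)ccc12`: 43200 nM
- compound 3 `Cc1cc(=O)oc2cc(OCC(=O)c3cccc(C(F)(F)F)c3)ccc12`: 38400 nM

Compound 1 stands at the low end of these numbers, though not clear of the whole set. Its value of 20700 nM lies within the usual scatter of compound 3 at 38400 nM. Only compound 2 at 43200 nM is separated from compound 1, and only just beyond the scatter.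

The next compound to be tested is compound 4 `Cc1cc(=O)oc2cc(OCC(=O)c3ccc(F)cc3)ccc12`. It carries fluoro in place of tert-butyl on an aromatic carbon, para to a large group (fluoro in place of tert-butyl on an aromatic carbon). Going by the values given here, no pair of measured compounds differs at a single place, so no measured step informs this change directly. Among the compounds with values here, the only guide is the narrow spread of the three numbers. Compound 2 , with a trifluoromethyl group, gives 43200 nM, and compound 3 , also with a trifluoromethyl group, gives 38400 nM.

On that basis, a small move toward a higher number is expected, one that may stay within the scatter. The estimated change is a 1.7-fold higher number from compound 1 to compound 4 (0.23 log units; within the scatter). For compound 4 the estimated value is 35000 nM, with an expected range of 16000 nM to 75000 nM.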

Compound 4, half-maximal inhibitory concentration: > 100000 nM
Compound 4: only a limit was reported; the forecaster's own chance of this, stated with the estimate: 15%; at least 2.8-fold (0.45 log units) between middle value and limit.
By their numbers in this assay, from the lowest: compounds 1, 3 and 2 (each within the scatter of the next, the first and the last beyond it). At a limit, above all of these: compound 4.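

Fluoro in place of tert-butyl on this aromatic carbon, para to a large group, is the first single-place change that can be read in the series, and in this assay it gives an at least 4.8-fold higher number from compound 1 to compound 4 (0.68 log units; beyond the scatter). The earlier compounds offered no such pair, so only now is it shown that the read-out responds to the group at this place, and that tert-butyl cannot be swapped for fluoro here without a clear shift toward weaker inhibition. Compound 4 gives > 100000 nM, which is a limit and not a number, and the full size of the step therefore stays unknown: the limit of > 100000 nM in this assay, at which 1 of the 4 values shown sits.

Going by these compounds, what remains open is how the read-out follows the group at this place, since a single step with one end at a limit gives no trend. Isopropyl, methoxy, chloro or an amine at the same aromatic carbon, on the core of compound 1, would each give a further single-place comparison and show whether activity falls away gradually or only with fluoro.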